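A chlorophenyl swap on the triazole nitrogen

This account rests on a few compounds, and the source may have more. Where it says the series, first, only, none or still open, it means among the compounds named here.

Four compounds built on a shared core are compared in a functional assay on OVCAR-3 cells (Homo sapiens) for antiproliferative activity, read by MTT assay, with a stated time of 24 h; on this read-out lower numbers stand for stronger inhibition and higher numbers for weaker inhibition. Compound 1 `O=c1[nH]cc(S(=O)(=O)Nc2ccccc2-c2cn(-c3ccccc3)nn2)c(=O)[nH]1` gives 6650 nM. Compound 2 `O=c1[nH]cc(S(=O)(=O)Nc2ccccc2-c2cn(-c3ccc(Cl)cc3)nn2)c(=O)[nH]1` carries a chloro group in place of a hydrogen on an aromatic carbon and gives 1750 nM. Among the compounds with values here, the only measured single change shows a 3.8-fold lower number from compound 1 to compound 2 (0.58 log units; beyond the scatter). Compound 3 `Cc1cccc(-n2cc(-c3ccc(NS(=O)(=O)c4c[nH]c(=O)[nH]c4=O)cc3)nn2)c1` gives 7490 nM, the highest of the three numbers; compound 1 sits within the usual scatter of it, while compound 2 gives a clearly lower number. Compound 4 `O=c1[nH]cc(S(=O)(=O)Nc2ccc(-c3cn(-c4ccc(Cl)cc4)nn3)cc2)c(=O)[nH]1` has not yet been tested. It differs from compound 3 by 4-chlorophenyl in place of 3-methylphenyl on an aromatic nitrogen. Within the data shown here, no measured pair swaps a methyl group for a chloro group directly, and the one step that brings in a chloro group, a 3.8-fold lower number from compound 1 to compound 2 (0.58 log units; beyond the scatter), arose on a different part of the structure. Among the measured compounds shown here, with only that step as a guide, a modest move toward a lower number is expected, a 2.5-fold lower number from compound 3 to compound 4 (0.40 log units; beyond the scatter). Compound 4 is therefore estimated at 3000 nM, with a range from 1200 nM to 7500 nM.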

Compound 4, half-maximal inhibitory concentration: 2160 nM
Estimate against measurement, compound 4: 1.4-fold (0.14 log units) above, within the range that was stated.
By their numbers in this assay, from the lowest: compounds 2 and 4 (each within the scatter of the next); then compounds 1 and 3 (each within the scatter of the next).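

In this assay, the swap on the aromatic nitrogen gives a 3.5-fold lower number from compound 3 to compound 4 (0.54 log units; beyond the scatter), so this position responds even when the two groups have the same count of heavy atoms and neither carries a hydrogen-bond donor or acceptor. Earlier, a chloro group had been seen only replacing a hydrogen, in the pair compound 1 and compound 2, whereas here 4-chlorophenyl gives the lower number against a substituted ring, 3-methylphenyl, in a different arrangement of the shared core. No measurement shown explains this step.

This single change alters both the substituent and its place on the ring, so 3-chlorophenyl and 4-methylphenyl would be needed to tell those two effects apart. Going by these compounds, how an amine or a carboxylic acid on this ring would read also remains open.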